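Series notes: cyclopropyl to tert-butoxy on the shared core

This account rests on a few compounds, and the source may have more. Where it says the series, first, only, none or still open, it means among the compounds named here.

Of the compounds shown here, two have been measured, and both carry the same core with a different side chain. Compound 1 `O=C(NCc1cc(Cl)ccc1-n1cnnn1)[C@@H]1[C@H]2C[C@H]2CN1C(=O)[C@H](O)CC1CC1` carries a cyclopropyl group there; compound 2 `O=C(NCc1cc(Cl)ccc1-n1cnnn1)[C@@H]1[C@@H]2C[C@@H]2CN1C(=O)[C@H](O)Cc1ccccn1` carries a pyridine-bearing chain. In a functional assay on a cell-free system (plasma, Homo sapiens), with a stated time of 3 min (on this read-out lower numbers stand for stronger inhibition and higher numbers for weaker inhibition), compound 1 gives 1400 nM. Compound 2 gives 1700 nM in this assay. Compound 1 thus stands with the lowest of the two numbers, but the gap to compound 2 lies within the usual scatter, so the two read as equal.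

Compound 3 `CC(C)(C)OC[C@@H](O)C(=O)N1C[C@@H]2C[C@@H]2[C@H]1C(=O)NCc1cc(Cl)ccc1-n1cnnn1` is not yet measured. Relative to compound 1 the change is tert-butoxy in place of cyclopropyl on a saturated chain carbon, two bonds along the chain from a carbonyl carbon and an oxygen on a saturated carbon. Going by the values given here, no step between measured compounds is known for this series, so any expectation rests on the two values alone: compound 1 at 1400 nM and compound 2 at 1700 nM sit together although their side chains differ, which suggests that the side chain tolerates change. The expected step is therefore a 1.1-fold higher number from compound 1 to compound 3 (0.03 log units; within the scatter), nothing beyond the scatter in either direction. For compound 3 the estimate in this assay is 1500 nM, with a range from 600 nM to 4000 nM.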

Compound 3, half-maximal inhibitory concentration: 570 nM
The estimate for compound 3 lay 2.6-fold (0.42 log units) above the measured number; the measured number lies below the stated range.
By their numbers in this assay, from the lowest: compound 3; then compounds 1 and 2 (each within the scatter of the next).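

In this assay, this position now responds to a change of side chain: tert-butoxy in place of cyclopropyl on a saturated chain carbon gives a 2.5-fold lower number from compound 1 to compound 3 (0.39 log units; beyond the scatter), a modest step beyond the scatter. The equal reading of compound 1 and compound 2 had suggested a side chain that tolerates change, but compound 3 stands apart from both with the lowest number, so the side chain does not tolerate every change without consequence. Nothing at hand bears on the reason for this lower number.

With a single step at this place, the compounds shown leave open whether the lower number goes with the oxygen of the tert-butoxy group, its carbon part or the loss of the three-membered ring. Also open, going by these compounds, is how a tert-butyl group, a longer alkoxy chain or an amine at this place would read in this assay, and whether tert-butoxy gives a step of similar size when paired with a different side chain or core.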